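Two Chlorines for a Methoxy on the Sulfonyl Arm

This account rests on a few compounds, and the source may have more. Where it says the series, first, only, none or still open, it means among the compounds named here.

Compound 1 `COc1ccc(S(=O)(=O)c2cnc3ccc(F)cc3c2N2CCC(C)CC2)cc1` was tested in an assay on isolated protein for displacement of a labelled ligand from metabotropic glutamate receptor 5 (Homo sapiens), with a stated time of 60 min, tested at 1 uM (on this read-out higher numbers stand for more inhibition at the one concentration tested (going by the name of the read-out) and lower numbers for less inhibition), where compound 1 gives 85%. Among the three measured numbers this stands second highest. Compound 2 `CC1CCN(c2c(S(=O)(=O)c3ccc(F)c(F)c3)cnc3c(F)cccc23)CC1` gives 93%, a value within the usual scatter of that of compound 1. Within the data shown here, compound 3 `COc1ccc(S(=O)(=O)c2cnc3ccc(OC)cc3c2N2CCC(C)CC2)cc1` gives 41%; the single change separating it from compound 1, methoxy in place of fluoro on an aromatic carbon of the shared core, brought a number 44 percentage points lower from compound 1 to compound 3 (beyond the scatter). Compound 4 `CC1CCN(c2c(S(=O)(=O)c3ccc(Cl)c(Cl)c3)cnc3ccc(F)cc23)CC1` differs from compound 1 elsewhere: 3,4-dichlorophenyl in place of 4-methoxyphenyl on a sulfonyl sulfur. Among the measured compounds shown here, no measured step alters this group alone, so the one known step does not bear directly on it; compound 2 differs from compound 1 in several places, including on the sulfonyl sulfur, yet its number lies within the scatter of compound 1. Compound 4 is therefore expected to show a number 2 percentage points higher from compound 1 to compound 4 (within the scatter), nothing beyond the scatter. The estimate for compound 4 is 87%, with a range from 68% to 98%.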

Compound 4, a percentage reported as inhibition, at one concentration (the size of the read-out at that concentration, not a potency): 91%
Estimate against measurement, compound 4: 4 percentage points below; measured number inside the range.
By their numbers in this assay, from the lowest: compound 3; then compounds 1, 4 and 2 (each within the scatter of the next).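

Among these compounds, putting 3,4-dichlorophenyl in place of 4-methoxyphenyl on a sulfonyl sulfur gives a number 6 percentage points higher from compound 1 to compound 4 (within the scatter) in this assay, the first step that alters this group alone. Among the compounds shown here, this position therefore accepts a full exchange of its aromatic group, whereas the single change on the shared core gave a number 44 percentage points lower from compound 1 to compound 3 (beyond the scatter). Nothing measured here gives a reason for this difference. Going by these compounds, whether a cyclohexyl ring or a single chlorine on the phenyl ring would hold the number stays open. A reading at one concentration also leaves any difference in potency between compound 1 and compound 4 unresolved.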